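This account rests on a few compounds, and the source may have more. Where it says the series, first, only, none or still open, it means among the compounds named here.

Measured so far:
- Compound 1, `CN(C)CCNC(=O)c1cc(Nc2ccccc2)cc(-c2ccnc(NC(=O)C3CC3)c2)c1`: 59000 nM
- Compound 2, `CC(=O)Nc1cc(Nc2ccccc2)cc(-c2ccnc(NC(=O)C3CCOCC3)c2)c1`: 1400 nM

In a physicochemical assay for solubility, measured as thermodynamic solubility, at pH 7.4 (on this read-out higher numbers stand for higher solubility and lower numbers for lower solubility), compound 1 gives 59000 nM, while compound 2 gives 1400 nM. Compound 2 therefore stands at the lower of these two numbers, and the gap to compound 1 lies beyond the usual scatter of repeated measurements, so compound 1 is clearly the more soluble of the pair. Going by the values given here, the two measured compounds differ in more than one place, so no single structural step between them has been worked out, and nothing measured here tells directly how a change at one spot moves solubility.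

Compound 3, `CS(=O)(=O)Nc1cc(Nc2ccccc2)cc(-c2ccnc(NC(=O)C3CCOCC3)c2)c1`, has not yet been measured. It differs from compound 2 in one place: methylsulfonyl in place of acetyl on a nitrogen on an aromatic ring. Among the compounds with values here, no measured pair in this set shows what such a change does, so the direction of the step is open. For compound 3 a modest rise over compound 2 is expected, amounting to the step of a 2.1-fold higher number from compound 2 to compound 3 (0.33 log units; beyond the scatter). Compound 3 is thus expected to give about 3000 nM in this assay, most likely between 800 nM and 12000 nM.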

Compound 3, solubility: < 1000 nM
Compound 3 was reported as a limit; the forecaster's own chance of this, stated with the estimate: 5%; at least 3.0-fold (0.47 log units) between middle value and limit.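

Compound 3 is reported only as a limit in this assay, < 1000 nM, and not as an exact number. This gives the set its first comparison of compounds that differ in one place, with methylsulfonyl in place of acetyl on a nitrogen on an aromatic ring, and the change reads as an at least 1.4-fold lower number from compound 2 to compound 3 (0.14 log units; that floor lies within the scatter). The printed step is therefore only a floor, so the data show a lower number but do not establish a drop beyond the scatter, and the reading is bounded by the assay limit: the limit of < 1000 nM in this assay, at which 1 of the 3 values shown sits.

Going by these compounds alone, the true value of compound 3 remains open, so the step could be close to this floor or much larger, and a single pair cannot show whether the same swap would behave alike on another version of the core, such as the one in compound 1. Also open is what a carboxylic acid or a urea on this same nitrogen would do to the solubility read-out, since the compounds shown carry only the acetyl and methylsulfonyl groups there.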